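This account rests on a few compounds, and the source may have more. Where it says the series, first, only, none or still open, it means among the compounds named here.

Measured in a functional assay on OVCAR-4 cells (Homo sapiens) for inhibition, read by sulforhodamine B assay, with a stated time of 48 h; a higher number here means a weaker inhibitor of growth, a lower number a stronger inhibitor of growth:
- compound 1 `O=C(Nc1cccc(-n2cc(-c3ccncc3)c(-c3ccc(Cl)c(O)c3)n2)c1)Nc1cccc(C(F)(F)F)c1`: 3180 nM
- compound 2 `O=C(Nc1cccc(-n2cc(-c3ccncc3)c(-c3ccc(Cl)c(O)c3)n2)c1)Nc1ccc(Cl)c(Cl)c1`: 1690 nM
- compound 3 `COc1cc(-c2nn(-c3cccc(NC(=O)Nc4ccc(Cl)c(C(F)(F)F)c4)c3)cc2-c2ccncc2)ccc1Cl`: 1290 nM

Compound 3 has the lowest number of the three; its gap to compound 2 lies within the scatter, its gap to compound 1 beyond it. Compound 4 `O=C(Nc1cccc(-n2cc(-c3ccncc3)c(-c3ccc(Cl)c(O)c3)n2)c1)Nc1ccc(Cl)c(C(F)(F)F)c1` differs from compound 3 by hydrogen in place of methyl on an oxygen on an aromatic ring. For the measured compounds named here, no measured step covers this change. Going by the values given here, the one measured step, a 1.9-fold lower number from compound 1 to compound 2 (0.27 log units; within the scatter), alters the aryl group on the amide-type nitrogen and so does not bear on it. Compounds 1 and 2 both carry the hydroxy group and give numbers near that of compound 3, so only a small step, if any, is expected in this assay. Compound 4 is estimated at 1800 nM, range 700 nM to 4500 nM. This estimate means a 1.4-fold higher number from compound 3 to compound 4 (0.14 log units; within the scatter), not expected to exceed the scatter.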

Compound 4, concentration for 50% growth inhibition: 1200 nM
Compound 4: middle estimate off by 1.5-fold (0.18 log units), on the high side; measured number inside the range.
By their numbers in this assay, from the lowest: compounds 4, 3, 2 and 1 (each within the scatter of the next, the first and the last beyond it).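

In this assay, hydroxy and methoxy on the 4-chloro-3-methoxyphenyl position cannot be told apart (a 1.1-fold lower number from compound 3 to compound 4 (0.03 log units; within the scatter)), so this oxygen carries either hydrogen or methyl without a readable difference. On the aryl group on the amide-type nitrogen, trifluoromethyl in place of chloro also stays within the scatter (a 1.4-fold lower number from compound 2 to compound 4 (0.15 log units; within the scatter)), whereas chloro in place of hydrogen goes beyond it (a 2.7-fold lower number from compound 1 to compound 4 (0.42 log units; beyond the scatter)). No evidence on the reason for any of these steps is available.

As far as these compounds go, whether a longer chain such as ethoxy, or an amine in place of the oxygen, would keep the number at this level remains open. So does whether hydroxy and methoxy also match with other aryl groups on the amide-type nitrogen.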